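Swapping a Pyridinyl Ring for Chlorine in a Cytotoxicity Series

A few compounds are considered here, and "the series" means these few. Any claim that something is new, unique, unknown or untested is made for them only; others in the source may bear on it.

Measured compounds:
compound 1 `N#Cc1ccc(NC(=O)c2cc(Br)c(-c3ccccc3)cc2O)cc1` — 850 nM
compound 2 `N#Cc1ccc(NC(=O)c2cc(-c3cccnc3)ccc2O)cc1` — 8330 nM
compound 3 `Cc1cccc(O)c1C(=O)Nc1ccc(C#N)cc1` — 7940 nM

In a functional assay on KG-1 cells (Homo sapiens) for cytotoxicity, read by luminescence and CellTiter-Glo, with a stated time of 3 days (a higher number here means a weaker inhibitor, a lower number a stronger inhibitor), compound 2 gives 8330 nM, the highest of the three numbers. Compound 3 at 7940 nM sits within the scatter of it, so the two cannot be told apart. Compound 1 at 850 nM stands beyond the scatter and is the stronger of that pair.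

Compound 4 `N#Cc1ccc(NC(=O)c2cc(Cl)ccc2O)cc1` is not yet measured. It differs from compound 2 in one place: chloro in place of pyridin-3-yl on an aromatic carbon.

For the measured compounds named here, no measured pair shows this change. With only one outcome to lean on, a modest drop in the number is expected, and the step of a 2.1-fold lower number from compound 2 to compound 4 (0.32 log units; beyond the scatter) from compound 2 to compound 4 is estimated at that size, with wide uncertainty. Compound 4 is expected at about 4000 nM, between 1000 nM and 15000 nM.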

Compound 4, half-maximal inhibitory concentration: 1860 nM
Compound 4: the middle estimate sits 2.2-fold (0.33 log units) above what was measured, and the stated range covers the measured number.
By their numbers in this assay, from the lowest: compound 1; then compound 4; then compounds 3 and 2 (each within the scatter of the next).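

In this assay, this position on the aromatic ring accepts a large change in size: replacing the whole pyridin-3-yl ring with a single chloro gives a 4.5-fold lower number from compound 2 to compound 4 (0.65 log units; beyond the scatter) and does not cost activity. The pyridin-3-yl ring is therefore not needed here for cytotoxicity in these cells, and the much smaller group does better. No measurement at hand explains why the number falls. An amine or a methoxy group at this place would show whether the gain is specific to chloro or extends to other small groups.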